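The source may hold more compounds than are shown below. What is called first, only, known or untested is meant among the compounds shown, and "the series" means these compounds.

In an assay on HEK293 cells for inhibition of Voltage-dependent T-type calcium channel subunit alpha-1G (Homo sapiens), read by fluorescence, tested at 10 uM (on this read-out lower numbers stand for less inhibition and higher numbers for more inhibition at the one concentration tested (going by the name of the read-out)), the shared core of compound 1 `CCCc1nc(-c2ccccc2)c(CNCCCN2CCN(c3ccccc3)CC2)o1` gives 43.7%, compound 2 `CCCc1nc(-c2ccccc2)c(CNCCCN2CCN(c3cccc(OC)c3)CC2)o1` gives 36.4%, and compound 3 `CCCc1nc(-c2ccccc2)c(CNCCCN2CCN(c3ccccc3C(F)(F)F)CC2)o1` gives 45%, the highest of the three numbers, though its steps to both neighbours stay within the scatter. Compound 4 `CCCc1nc(-c2ccccc2)c(CNCCCN2CCN(c3cccc(C(F)(F)F)c3)CC2)o1` differs from compound 3 by 3-(trifluoromethyl)phenyl in place of 2-(trifluoromethyl)phenyl on an amine nitrogen in a ring. Going by the values given here, two measured steps touch this change of the aromatic group on the ring nitrogen: a number 1.3 percentage points higher from compound 1 to compound 3 (within the scatter) and a number 8.6 percentage points higher from compound 2 to compound 3 (within the scatter), both within the scatter. A step of no size beyond the scatter is therefore expected for a number 3 percentage points lower from compound 3 to compound 4 (within the scatter) in this assay. Compound 4 is accordingly estimated at 42%, within a range from 28% to 56%.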

Compound 4, a percentage reported as inhibition, at one concentration (the size of the read-out at that concentration, not a potency): 51.6%
Estimate against measurement, compound 4: 9.6 percentage points below, and the stated range covers the measured number.
By their numbers in this assay, from the lowest: compounds 2, 1, 3 and 4 (each within the scatter of the next, the first and the last beyond it).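

In this assay, 3-(trifluoromethyl)phenyl in place of 2-(trifluoromethyl)phenyl gives a number 6.6 percentage points higher from compound 3 to compound 4 (within the scatter) and trifluoromethyl in place of hydrogen gives a number 7.9 percentage points higher from compound 1 to compound 4 (within the scatter), so neither change separates these compounds. Trifluoromethyl in place of methoxy, however, gives a number 15.2 percentage points higher from compound 2 to compound 4 (beyond the scatter), the only step among these compounds that lies beyond the scatter. No measured finding accounts for this step. From the compounds shown here alone, what stays open is how a chlorine on the aromatic ring, or a pyridine in place of the phenyl on the ring nitrogen, would read in this assay.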